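Replacing a Triazolylmethyl Side Chain with a Carbamoyl Group

The source may hold more compounds than are shown below. What is called first, only, known or untested is meant among the compounds shown, and "the series" means these compounds.

Compound 3 `O=C1O[C@@H](Cn2ccnn2)CN1c1ccc(-n2cc(-c3ccccn3)cn2)c(F)c1` was tested in an ADME assay on HEK293-A cells (Homo sapiens) for cytotoxicity, read by MTT assay, with a stated time of 48 h (a higher number here means a weaker inhibitor, a lower number a stronger inhibitor), and gives 225 ug/mL. Among the numbers recorded it is the highest of the two, and its nearest neighbour is compound 1 `CN1CCN(C[C@H]2CN(c3ccc(-n4cc(-c5ccccn5)cn4)c(F)c3)C(=O)O2)CC1`, which gives 70 ug/mL. Compound 2 `O=C1CCC(=O)N1C[C@H]1CN(c2ccc(-n3cc(-c4ccccn4)cn3)c(F)c2)C(=O)O1` reaches only a limit of this assay, > 400 ug/mL. That limit is the one at the limit of > 400 ug/mL in this assay, at which 1 of the 3 values shown sits.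

The measured steps all change the same side group on the shared core: an at least 5.7-fold higher number from compound 1 to compound 2 (0.75 log units; beyond the scatter), a 3.2-fold higher number from compound 1 to compound 3 (0.51 log units; beyond the scatter) and an at least 1.7-fold lower number from compound 2 to compound 3 (0.24 log units; that floor lies within the scatter). The step to compound 4 `NC(=O)[C@H]1CN(c2ccc(-n3cc(-c4ccccn4)cn3)c(F)c2)C(=O)O1` again alters this position: carbamoyl in place of (1H-1,2,3-triazol-1-yl)methyl on a saturated ring carbon. Among the measured compounds shown here, no measured step introduces a carbamoyl group, so the steps give only a sense of scale, and they show modest movement at most. The expected change is therefore small, a 1.1-fold higher number from compound 3 to compound 4 (0.05 log units; within the scatter), and compound 4 is estimated at 250 ug/mL, likely between 110 ug/mL and 420 ug/mL, with a fair chance that only a limit is reported.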

Compound 4, half-maximal inhibitory concentration: 152 ug/mL
Beside the measured number, compound 4's estimate is 1.6-fold (0.22 log units) above it; the measured number falls inside the stated range.
By their numbers in this assay, from the lowest: compound 1; then compounds 4 and 3 (each within the scatter of the next). At a limit, above all of these: compound 2.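

In this assay, a carbamoyl group, which has no ring and no chain carbon linking it to the saturated ring carbon, takes the place of the (1H-1,2,3-triazol-1-yl)methyl group with no clear change: a 1.5-fold lower number from compound 3 to compound 4 (0.17 log units; within the scatter). The (4-methylpiperazin-1-yl)methyl group still gives the lowest number of the four, as it does against every other group here, and the carbamoyl comparison reads a 2.2-fold higher number from compound 1 to compound 4 (0.34 log units; beyond the scatter). The step of an at least 2.6-fold lower number from compound 2 to compound 4 (0.42 log units; beyond the scatter) starts from a limit of the assay, not a number: the limit of > 400 ug/mL in this assay, at which 1 of the 4 values shown sits.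

As far as these compounds go, it remains open whether a carboxylic acid or an N,N-dimethylcarbamoyl group at this position would read like the carbamoyl group. From the compounds shown here alone, it is also open whether a simple aminomethyl group would bring the number down towards that of compound 1.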